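The source may report more compounds than this note shows. Statements on the series, on what has been measured and on what is new or still open speak of the compounds shown alone.

In a functional assay on HOP-62 cells (Homo sapiens) for inhibition, read by sulforhodamine B assay (on this read-out lower numbers stand for stronger inhibition of growth and higher numbers for weaker inhibition of growth), compound 1 (`Cc1ccc2[nH]c(-c3ccc(-c4ccc(-c5ccc(N(C)C)cc5)cc4)cc3)nc2c1`) gives 4230 nM, compound 2 (`Cc1ccc2[nH]c(-c3ccc(-c4ccc(-c5cccc(Cl)c5)cc4)cc3)nc2c1`) gives 2740 nM and compound 3 (`COc1ccc(-c2ccc(-c3ccc(-c4nc5cc(C)ccc5[nH]4)cc3)cc2)cc1OC`) gives 2120 nM. Compound 1 thus stands within the usual scatter of both neighbours, and the three values do not separate. Compound 4 (`CN(C)c1ccc(-c2ccc(-c3ccc(-c4nc5c(O)cccc5[nH]4)cc3)cc2)cc1`) keeps the 4-(dimethylamino)phenyl group of compound 1 and exchanges the other end of the molecule, with 4-hydroxy-1H-benzimidazol-2-yl in place of 5-methyl-1H-benzimidazol-2-yl on an aromatic carbon. The measured steps bear on this only indirectly, since all of them change the opposite end: a 1.5-fold lower number from compound 1 to compound 2 (0.19 log units; within the scatter), a 2.0-fold lower number from compound 1 to compound 3 (0.30 log units; within the scatter) and a 1.3-fold lower number from compound 2 to compound 3 (0.11 log units; within the scatter). Going by the values given here, no measured compound varies the 5-methyl-1H-benzimidazol-2-yl group, so the data offer no direct guide to this exchange, and no shift beyond the scatter can be argued from them. The expected step is a 1.4-fold lower number from compound 1 to compound 4 (0.15 log units; within the scatter), with wide uncertainty. For compound 4 the estimated value is 3000 nM, with an expected range from 800 nM to 10000 nM.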

Compound 4, concentration for 50% growth inhibition: 8250 nM
Compound 4: middle estimate off by 2.8-fold (0.44 log units), on the low side; low and high end bracket the measured number.
By their numbers in this assay, from the lowest: compounds 3, 2, 1 and 4 (each within the scatter of the next, the first and the last beyond it).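

The exchange of 5-methyl-1H-benzimidazol-2-yl for 4-hydroxy-1H-benzimidazol-2-yl is the first change shown at this end of the molecule, and in this assay it gives a 2.0-fold higher number from compound 1 to compound 4 (0.29 log units; within the scatter). Compound 4 therefore does not separate from compound 1, so this end, like the opposite end in the earlier compounds, has so far shown no shift beyond the scatter. No measurement at hand gives a cause for this step.

The compounds shown leave open whether the loss of the methyl group or the arrival of the hydroxy group sets the step, and how a methoxy group, an amine or a carboxylic acid would read on this end. Also open, going by these compounds, is whether the same exchange would read alike with the 3-chlorophenyl group of compound 2 or the 3,4-dimethoxyphenyl group of compound 3 at the other end.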